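The source may hold more compounds than are shown below. What is called first, only, known or untested is meant among the compounds shown, and "the series" means these compounds.

Within the data shown here, in a functional assay on QGY7701 cells (Homo sapiens) for cytotoxicity, read by MTT assay, with a stated time of 24 h (a lower number here means a stronger inhibitor, a higher number a weaker inhibitor), compound 2 `C=CC1=C(C(=O)NCCC)C(c2ccc(Cl)c(Cl)c2)OC1` gives 31300 nM, the only number reported among the two values shown. Compound 1 `C=CC1=C(C(=O)NCCCCC)C(c2ccc(Cl)c(Cl)c2)OC1` sits at the limit described by the limit of > 100000 nM in this assay, at which 1 of the 2 values shown sits. In this assay compound 1 gives > 100000 nM, a limit rather than a number. Among the measured compounds shown here, the sole measured step is an at least 3.1-fold lower number from compound 1 to compound 2 (0.50 log units; beyond the scatter). Compound 3 `C=CC1=C(C(=O)NCC(C)C)C(c2ccc(Cl)c(Cl)c2)OC1` differs from compound 2 by methyl in place of hydrogen on a saturated chain carbon bound to two saturated chain carbons. That measured step shortened the chain, whereas here a single methyl is added, so the estimated step of a 1.3-fold higher number from compound 2 to compound 3 (0.11 log units; within the scatter) is expected to stay within the scatter. Compound 3 is accordingly estimated at 40000 nM, between 15000 nM and 100000 nM.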

Compound 3, half-maximal inhibitory concentration: > 100000 nM
Compound 3: only a limit was reported; the forecaster's own chance of this, stated with the estimate: 25%; middle value at least 2.5-fold (0.39 log units) away from the limit.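

In this assay, among these compounds, the earlier compounds showed only a change in chain length, whereas a single methyl on a saturated chain carbon bound to two saturated chain carbons also matters, with an at least 3.1-fold higher number from compound 2 to compound 3 (0.50 log units; beyond the scatter). Propyl to isobutyl is thus enough to move the reading from a number to a limit. The step between compound 1 and compound 3 cannot be read, and both sit at the same limit: the limit of > 100000 nM in this assay, at which 2 of the 3 values shown sit.

As far as these compounds go, it remains open whether a shorter chain such as ethyl, or an amine or a carboxylic acid at the chain end, would give a lower number than compound 2.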